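Nitro to trifluoromethyl on the benzyl ring of compound 1

A few compounds are considered here, and "the series" means these few. Any claim that something is new, unique, unknown or untested is made for them only; others in the source may bear on it.

Measured compounds: compound 1 `O=[N+]([O-])c1cccc(CNc2cc(C(F)(F)F)cc3[nH]ncc23)c1`, 82%; compound 2 `Cc1ccc(CNc2cc(C(F)(F)F)cc3[nH]ncc23)c([N+](=O)O)c1`, 92%; compound 3 `O=[N+]([O-])c1cccc(CNc2cc(Br)cc3[nH]ncc23)c1`, 97%.

In an assay for inhibition of Tryptophan 2,3-dioxygenase (Homo sapiens), with stated times of 10 min and 60 min, tested at 100 uM (on this read-out higher numbers stand for a stronger effect at the one concentration tested and lower numbers for a weaker effect), compound 1 gives 82%, the lowest of the three numbers. The number for compound 2 lies within the scatter of it, whereas compound 3 stands beyond the scatter, the step being a number 15 percentage points higher from compound 1 to compound 3 (beyond the scatter). Compound 4 `FC(F)(F)c1cccc(CNc2cc(C(F)(F)F)cc3[nH]ncc23)c1` differs from compound 1 by trifluoromethyl in place of nitro on an aromatic carbon. For the measured compounds named here, the one measured step concerns a change on the core, not this change, so nothing measured bears on it directly. With no guide, the number for compound 4 is expected to stay near that of compound 1: the estimated step is a number 4 percentage points lower from compound 1 to compound 4 (within the scatter), and compound 4 is estimated at 78%, between 55% and 95%.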

Compound 4, a percentage reported as inhibition, at one concentration (the size of the read-out at that concentration, not a potency): 74%
For compound 4 the middle estimate is 4 percentage points above the measured one; the range from low to high includes it.
By their numbers in this assay, from the lowest: compounds 4, 1, 2 and 3 (each within the scatter of the next, the first and the last beyond it).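

In this assay, trifluoromethyl in place of nitro gives a number 8 percentage points lower from compound 1 to compound 4 (within the scatter). This is the first step shown at this position rather than on the core, and it shows that a group with 2 hydrogen-bond acceptors can give way to one with 0 without a change beyond the scatter. Nothing measured here gives a reason for this result. Going by these compounds, whether an amine, a carboxylic acid or a nitrile at this position would give a similar number remains open. So does whether the same exchange would read alike with bromo on the core.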